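Replacing Chloro With Methylcarbamoyl in a Cytotoxicity Series

The compounds below may be only part of what the source reports. "The series", "measured", "known", "first", "only" and "open" are said of these compounds alone.

Compound 1 `COC(=O)c1ccc(NCc2cncn2Cc2ccccc2C(C)(C)C)cc1-c1ccccc1` and compound 2 `Nc1cc(-c2ccccc2)ccc1Cn1cncc1CNc1ccc(Cl)c(-c2ccccc2)c1` share a common core. In a toxicity assay on NIH3T3 cells (Mus musculus) for cytotoxicity, read by resazurin assay (on this read-out higher numbers stand for an effect only at larger amounts of compound and lower numbers for an effect already at smaller amounts), compound 1 gives "not determined" (no result reported), so it offers no point of comparison. For compound 2 the result in this assay is a limit of the assay, > 1000 nM. Compound 2 therefore sits at the limit of > 1000 nM in this assay, at which 1 of the 2 values shown sits, and no single number places it on the scale. Compound 3 `CNC(=O)c1ccc(NCc2cncn2Cc2ccc(-c3ccccc3)cc2N)cc1-c1ccccc1` differs from compound 2 in one place: methylcarbamoyl in place of chloro on an aromatic carbon. Within the data shown here, no measured step of this kind is available between the two compounds, so the size of the change can only be anticipated. Because compound 2 shows > 1000 nM, compound 3 is expected to remain near or beyond that same limit, giving an expected step that the limit leaves unreadable from compound 2 to compound 3 that stays within the usual scatter. The estimate for compound 3 in this assay is 3000 nM, with a range from 1000 nM to 30000 nM.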

Compound 3, half-maximal effective concentration: > 1000 nM
Compound 3 was reported as a limit (the forecaster's own chance of this, stated with the estimate: 80%); the middle value is on the limit's open side.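

In this assay compound 2 and compound 3 are both reported only as limits, and no step can be read between them: the limit of > 1000 nM in this assay, at which 2 of the 3 values shown sit. The compounds shown leave open where either compound lies on the scale, and whether methylcarbamoyl in place of chloro shifts the read-out at all.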